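From Isopropylamino to Azetidin-1-yl on the Amide Carbonyl

The source may report more compounds than this note shows. Statements on the series, on what has been measured and on what is new or still open speak of the compounds shown alone.

Of the compounds shown here, two with a shared core have been measured so far. In a functional assay on MDA-MB-468 cells (Homo sapiens) for antiproliferative activity, read by sulforhodamine B assay, with a stated time of 4 days (on this read-out higher numbers stand for weaker inhibition of growth and lower numbers for stronger inhibition of growth), compound 1 (`COc1cc(Cl)c(-c2nc(SCC(=O)NC3CC3)nc3[nH]cc(C#N)c23)cc1OC`) gives 62 nM and compound 2 (`COc1cc(Cl)c(-c2nc(SCC(=O)NC(C)C)nc3[nH]cc(C#N)c23)cc1OC`) gives 102 nM on the same scale. For the measured compounds named here, these two values lie within the scatter of each other, so compound 2 cannot be told apart from its only measured neighbour.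

The next structure, compound 3 (`COc1cc(Cl)c(-c2nc(SCC(=O)N3CCC3)nc3[nH]cc(C#N)c23)cc1OC`), alters compound 2 in one place: azetidin-1-yl in place of isopropylamino on a carbonyl carbon. Going by the values given here, only one measured step bears on this change, namely isopropyl in place of cyclopropyl on an amide-type nitrogen (a 1.6-fold higher number from compound 1 to compound 2 (0.22 log units; within the scatter)). That step is small, but both of its compounds keep the amide hydrogen, which compound 3 lacks. Among the compounds with values here, no measured compound shows what losing it does, so the guide is weak. No step beyond the scatter is expected, and the estimated move is small (a 1.3-fold higher number from compound 2 to compound 3 (0.11 log units; within the scatter)), though the uncertainty stays wide. In this assay the expected value for compound 3 is 130 nM within an estimated range from 40 nM to 420 nM at its upper end.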

Compound 3, concentration for 50% growth inhibition: 35 nM
Beside the measured number, compound 3's estimate is 3.7-fold (0.57 log units) above it, outside the stated range (below it).
By their numbers in this assay, from the lowest: compounds 3, 1 and 2 (each within the scatter of the next, the first and the last beyond it).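

In this assay, this position on the carbonyl carbon now shows a step beyond the scatter (a 2.9-fold lower number from compound 2 to compound 3 (0.46 log units; beyond the scatter)), which the earlier pair of compounds did not show. Azetidin-1-yl has no hydrogen-bond donor, so compound 3 shows that growth inhibition in these compounds survives the loss of the amide hydrogen, and the comparison with the cyclopropylamino amide, which keeps that hydrogen, stays within the scatter (a 1.8-fold lower number from compound 1 to compound 3 (0.25 log units; within the scatter)), leaving compound 1 and compound 3 indistinguishable. The change from compound 2 to compound 3 removes the amide hydrogen and closes a four-membered ring in one move, and nothing here explains why the number shifts.

The compounds shown cannot say which of those two features carries the step, and a dimethylamino group on the same carbonyl carbon, open-chained and also without an amide hydrogen, would help pull them apart. From the compounds shown here alone, how far the ring can grow also stays open, for instance whether pyrrolidin-1-yl or piperidin-1-yl at this place would hold the value of compound 3 (35 nM).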